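From thiophen-3-yl to iodo on the shared core

A few compounds are considered here, and "the series" means these few. Any claim that something is new, unique, unknown or untested is made for them only; others in the source may bear on it.

- Compound 1 `Nc1nc(N)c2c(-c3ccsc3)cn([C@@H]3O[C@H](CO)[C@@H](O)[C@H]3O)c2n1`: > 20000 nM
- Compound 2 `Cc1nc(N)c2c(-c3ccsc3)cn([C@@H]3O[C@H](CO)[C@@H](O)[C@H]3O)c2n1`: > 20000 nM

In a functional assay on CCRF-CEM cells (Homo sapiens), read by MTT assay, with a stated time of 72 h (on this read-out higher numbers stand for weaker inhibition and lower numbers for stronger inhibition), compound 2 gives > 20000 nM, which is a limit and not a number. Compound 1 gives > 20000 nM, also a limit. Both measured compounds thus stand at the limit of > 20000 nM in this assay, at which 2 of the 2 values shown sit.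

Compound 3 `Cc1nc(N)c2c(I)cn([C@@H]3O[C@H](CO)[C@@H](O)[C@H]3O)c2n1` carries iodo in place of thiophen-3-yl on an aromatic carbon. Among the measured compounds shown here, the only measured step, a step that the two limits leave unreadable from compound 1 to compound 2, involves a different change and has no readable size, so it offers no size to carry over. A shift towards stronger inhibition in this assay is nevertheless expected, though the read-out may remain a limit. The expected step is an at least 1.6-fold lower number from compound 2 to compound 3 (0.22 log units; that floor lies within the scatter). For compound 3 the estimated value is 12000 nM, with an expected range from 2000 nM to 20000 nM.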

Compound 3, half-maximal inhibitory concentration: 9030 nM
For compound 3 the middle estimate is 1.3-fold (0.12 log units) above the measured one; the range from low to high includes it.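

In this assay the change to iodo from thiophen-3-yl gives an at least 2.2-fold lower number from compound 2 to compound 3 (0.34 log units; beyond the scatter) and so shows that this place, two ring bonds from the ring nitrogen, can move the read-out. The step between the two earlier compounds could not be read. Compound 3 is the first compound here with a number, and the other two remain at a limit: the limit of > 20000 nM in this assay, at which 2 of the 3 values shown sit.

From the compounds shown here alone, whether iodo itself matters, or only the loss of the thiophen-3-yl ring, stays open. Going by these compounds, how a bromo or a phenyl group at this place would read also stays open.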